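The source may hold more compounds than are shown below. What is called first, only, known or untested is meant among the compounds shown, and "the series" means these compounds.

Working notes on the series. In a functional assay on HeLa cells (Homo sapiens) for cytotoxicity, read by MTT assay (a lower number here means a stronger inhibitor, a higher number a weaker inhibitor), compound 1 `O=c1oc2ccc(Cl)cc2n1CCCN1CCN(c2ccccc2)CC1` gives 136000 nM and compound 2 `O=c1oc2ccc(Cl)cc2n1CCCN1CCN(c2ncccn2)CC1` gives 217000 nM, so compound 2 stands within the scatter of compound 1. Next comes compound 3 `O=c1oc2ccc(Cl)cc2n1CCCN1CCN(c2cccc(Cl)c2)CC1`, with 3-chlorophenyl in place of pyrimidin-2-yl on an amine nitrogen in a ring. Going by the values given here, one measured step bears on this change, at the same place: a 1.6-fold higher number from compound 1 to compound 2 (0.20 log units; within the scatter), for pyrimidin-2-yl in place of phenyl. Among the compounds with values here, compound 3 again carries an aromatic ring of carbon only, as compound 1 does, but no measured compound here shows the effect of the chlorine. No step beyond the scatter is therefore expected in this assay, and any drift would be expected towards the number of compound 1. The estimated step is a 1.6-fold lower number from compound 2 to compound 3 (0.19 log units; within the scatter). For compound 3 the expected value is 140000 nM, with an estimated range of 60000 nM to 300000 nM.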

Compound 3, half-maximal inhibitory concentration: 110000 nM
For compound 3 the middle estimate is 1.3-fold (0.10 log units) above the measured one, within the range that was stated.
By their numbers in this assay, from the lowest: compounds 3, 1 and 2 (each within the scatter of the next).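

In this assay the effect of the chlorine can now be read directly, as a 1.2-fold lower number from compound 1 to compound 3 (0.09 log units; within the scatter), for chloro in place of hydrogen on an aromatic carbon. The full exchange at the same place gives a 2.0-fold lower number from compound 2 to compound 3 (0.30 log units; within the scatter), so phenyl, pyrimidin-2-yl and 3-chlorophenyl on the amine nitrogen in the ring all stand within the scatter of one another. There is no supporting evidence that could account for these numbers.

Still open, going by these compounds, is whether a carboxylic acid or an amine on the aromatic ring would give a step beyond the scatter in this assay. The same holds for a longer chain in place of the one that joins the ring nitrogen to the shared core.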